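Adding a Second Fluorine to the Aryl Ring of Compound 2

The compounds below may be only part of what the source reports. "The series", "measured", "known", "first", "only" and "open" are said of these compounds alone.

Compound 1 `COc1ccc(OC)c(-c2nc(C(c3ccccc3)c3ccccc3)sc2CC(=O)O)c1` gives 80% in an in vitro functional assay on HEK285-7 cells for antagonist activity at prostaglandin D2 receptor 2 (Homo sapiens), read by BRET and beta-arrestin recruitment; a higher number here means a larger maximal response, a lower number a smaller maximal response.
Compound 2 `O=C(O)Cc1sc(C(c2ccccc2)c2ccccc2)nc1-c1ccc(F)cc1` gives 80% in this assay.
Compound 3 `O=C(O)Cc1sc(C(c2ccccc2)c2ccc(Cl)cc2)nc1-c1ccc(F)cc1` gives 80% in this assay.

On these numbers compound 2 stands level with compounds 1 and 3: its nearest neighbour is compound 1 and its furthest is compound 3, and in neither direction does the gap leave the scatter. The two measured steps say the same. From compound 1 to compound 2 the aryl group on the shared core was exchanged, with no change at the digits printed from compound 1 to compound 2 (within the scatter), and from compound 2 to compound 3 a chloro entered on an aromatic carbon, with no change at the digits printed from compound 2 to compound 3 (within the scatter). Neither change to the aryl substitution moved the maximal response.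

Compound 4 `O=C(O)Cc1sc(C(c2ccccc2)c2ccccc2)nc1-c1ccc(F)c(F)c1` differs from compound 2 by fluoro in place of hydrogen on an aromatic carbon. The step that bears most directly on it is the halogen entry on an aromatic carbon from compound 2 to compound 3, which left this assay untouched, and the aryl exchange from compound 1 to compound 2 points the same way. The expected step in this assay is therefore none beyond the scatter, with no change at the digits printed from compound 2 to compound 4 (within the scatter). For compound 4 the estimated value in this assay is 80%, expected to lie between 70% and 90%.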

Compound 4, largest response reached (reported as efficacy), in percent of the reference or control that the assay uses: 80%
The estimate for compound 4 equals the measured number at the digits printed; measured number inside the range.
By their numbers in this assay, from the lowest: compounds 1, 2, 3 and 4 (each within the scatter of the next).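

In this assay, a fluoro ortho to the existing fluoro group, turning 4-fluorophenyl into 3,4-difluorophenyl, gave no change at the digits printed from compound 2 to compound 4 (within the scatter), so this aromatic carbon took a second halogen with the maximal response held. The chloro of compound 3 sits on a different aromatic ring, which makes compound 4 the first case here of a single-atom change on the fluorophenyl itself rather than an exchange of the whole aryl group. Set against the 2,5-dimethoxyphenyl group, the 3,4-difluorophenyl group gave no change at the digits printed from compound 1 to compound 4 (within the scatter), so this read-out does not tell these two substitution patterns on the aryl ring apart.

Nothing shown accounts for why the maximal response stays so flat across these changes. Still open, on these data alone, is whether an amine, a carboxylic acid or a longer chain in place of this second fluoro would keep the response at the same level, and whether a second fluoro on another carbon of that ring would do so.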